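Urea-end change from compound 3 to compound 4

The compounds below may be only part of what the source reports. "The series", "measured", "known", "first", "only" and "open" are said of these compounds alone.

Measured so far:
compound 1 `COc1ccc(Cl)cc1C(=O)NCC1CCN(S(=O)(=O)NC(=O)NC2CCCCC2)CC1`: 20%
compound 2 `COc1ccc(Cl)cc1C(=O)NCCC1CCN(S(=O)(=O)NC(=O)NC2CCCCC2)CC1`: 25%
compound 3 `COc1ccc(Cl)cc1C(=O)NCCC1CCN(S(=O)(=O)NC(=O)NC[C@@H]2C[C@@H]3C=C[C@@H]2C3)CC1`: 37%

In a functional assay on the whole organism (blood) with Rattus norvegicus as the target, with stated times of 24 h and 1 h, at a dose of 5 mg/kg by the intraperitoneal route (a lower number here means a weaker effect, a higher number a stronger effect of the compound at the dose given), compound 3 stands highest of the three numbers; compound 2 lies nearest and compound 1 furthest, both beyond the scatter. Among the measured compounds shown here, the only measured step that reaches compound 3 is a number 12 percentage points higher from compound 2 to compound 3 (beyond the scatter), a modest gain on the urea nitrogen when the six-membered ring gives way to the two five-membered rings.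

Compound 4 `CCCNC(=O)NS(=O)(=O)N1CCC(CCNC(=O)c2cc(Cl)ccc2OC)CC1` is still to be measured in this assay. It differs from compound 3 in one place: a group of 2 heavy atoms (2 carbon; no ring) in place of a group of 7 heavy atoms (7 carbon; 2 five-membered non-aromatic rings of carbon only), on a saturated chain carbon bound to an amide-type nitrogen. This undoes the bulkier urea substituent of compound 3 and goes further, to a short open chain with no ring at all. The step of a number 12 percentage points higher from compound 2 to compound 3 (beyond the scatter) suggests the ring-bearing urea end carried the gain of compound 3, so the reverse direction is expected here, and the small chain is not expected to recover what the six-membered ring of compound 1 and compound 2 gave. The estimated step is a number 19 percentage points lower from compound 3 to compound 4 (beyond the scatter). Compound 4 is therefore expected to give 18% in this assay, within a range from 5% to 35%.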

Compound 4, a percentage reported as activity, at one dose (the size of the read-out at that dose, not a potency): 11%
Estimate against measurement, compound 4: 7 percentage points above, within the range that was stated.
By their numbers in this assay, from the lowest: compounds 4, 1 and 2 (each within the scatter of the next, the first and the last beyond it); then compound 3.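

In this assay the open chain falls under both ring-bearing urea ends, with a number 26 percentage points lower from compound 3 to compound 4 (beyond the scatter) and a number 14 percentage points lower from compound 2 to compound 4 (beyond the scatter) on the same shared core. Among the compounds shown here, the earlier compounds showed only one ring group in place of another, whereas propyl in place of cyclohexyl on an amide-type nitrogen shows that losing the ring altogether also lowers the number beyond the scatter, and none of these three compounds goes against that. No measured evidence bears on why the number falls with this change.

As far as these compounds go, whether the ring itself or only the number of carbons sets the read-out stays open, and a longer chain such as hexyl on the urea end would separate the two. A phenyl ring or an amine at this place would show whether a group other than a saturated carbon ring or chain can hold the effect.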